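Series notes: aryl-alkynyl hydroxypentynes, cytotoxicity on breast carcinoma cells

The source may hold more compounds than are shown below. What is called first, only, known or untested is meant among the compounds shown, and "the series" means these compounds.

Measured so far:
compound 1 `OCCCCC#Cc1ccccc1C#Cc1ccccn1`, 25100 nM
compound 2 `OCCCCC#Cc1ccccc1C#Cc1ccccc1C(F)(F)F`, 800 nM

In a functional assay on MDA-MB-435 cells (Homo sapiens) for cytotoxicity (on this read-out higher numbers stand for weaker inhibition of growth and lower numbers for stronger inhibition of growth), compound 1 gives 25100 nM, the highest of the two numbers recorded; compound 2 gives 800 nM, a gap beyond the scatter. For the measured compounds named here, no pair of measured compounds differing in a single place is available, so no step has been computed.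

Compound 3 `OCCCCC#Cc1ccccc1C#Cc1cccc(O)c1` is the next entry; it differs from compound 1 in one place: 3-hydroxyphenyl in place of pyridin-2-yl on a triple-bonded carbon. Going by the values given here, the only comparison at hand is that of compound 1 with compound 2, where a carbocyclic ring at that position accompanies a much lower number. On that basis compound 3 is expected to fall below compound 1, with a step of a 5.0-fold lower number from compound 1 to compound 3 (0.70 log units; beyond the scatter) in this assay, though the direction and size remain uncertain. The estimate for compound 3 is 5000 nM, in the range 1000 nM to 25000 nM.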

Compound 3, concentration for 50% growth inhibition: 16100 nM
Compound 3: middle estimate off by 3.2-fold (0.51 log units), on the low side, within the range that was stated.
By their numbers in this assay, from the lowest: compound 2; then compounds 3 and 1 (each within the scatter of the next).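

In this assay, 3-hydroxyphenyl in place of pyridin-2-yl on a triple-bonded carbon gives a 1.6-fold lower number from compound 1 to compound 3 (0.19 log units; within the scatter) and leaves the two compounds unseparated. A ring of carbon only at this place is therefore not enough on its own to set a compound apart from compound 1, even with the hydrogen-bond donor that 3-hydroxyphenyl brings and pyridin-2-yl does not. No measurement at hand bears on the reason for this result.

Open, on these data alone, is whether plain phenyl, 3-methoxyphenyl or 3-aminophenyl on the same triple-bonded carbon would separate from compound 1 in this assay. Also open, as far as these compounds go, is how much of the outcome for compound 3 rests on the hydroxy group itself, since the ring and the hydroxy group change together in this single step.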